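One Carbon Longer on the Sulfur Chain: What to Expect

A few compounds are considered here, and "the series" means these few. Any claim that something is new, unique, unknown or untested is made for them only; others in the source may bear on it.

Compound 1 `C=CCSC[C@H](NC(=O)c1cc(O)c(O)c(O)c1)C(=O)OC` gives 52100 nM in an assay on RAW264.7 cells for antagonist activity at Toll-like receptor 2 (Mus musculus), read by Griess assay, with a stated time of 24 h; a lower number here means a stronger inhibitor, a higher number a weaker inhibitor.
Compound 2 `C=CCCSC[C@H](NC(=O)c1cc(O)c(O)c(O)c1)C(=O)OC` gives 57800 nM in this assay.
Compound 3 `C=CCCSC[C@H](NC(=O)c1ccc(O)cc1)C(=O)OC` gives 54900 nM in this assay.

All three numbers sit close together. Compound 1 and compound 2 share one core and differ in a single place: allyl in place of vinyl on a saturated chain carbon bound to a sulfur. The step of a 1.1-fold higher number from compound 1 to compound 2 (0.05 log units; within the scatter), so the longer chain made no difference that the assay can resolve. Compound 3 carries a different core; the difference between the core of compound 1 and the core of compound 3 is not broken down here. What the two values show is simply that compound 3 and compound 1 lie within the scatter of each other.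

Compound 4 `C=CCCCSC[C@H](NC(=O)c1ccc(O)cc1)C(=O)OC` has not yet been measured. It differs from compound 3 in one place: allyl in place of vinyl on a saturated chain carbon, two bonds along the chain from a sulfur. This is the same kind of change as the one from compound 1 to compound 2, and it occurs twice among these compounds, but the place is not identical: earlier it sat on a saturated chain carbon bound to a sulfur, here on a saturated chain carbon, two bonds along the chain from a sulfur. Because the earlier step of a 1.1-fold higher number from compound 1 to compound 2 (0.05 log units; within the scatter) stayed within the scatter, the step from compound 3 to compound 4 is expected to be small as well, a 1.1-fold higher number from compound 3 to compound 4 (0.02 log units; within the scatter). On that basis compound 4 is estimated to give 58000 nM in this assay. The expected range for compound 4 runs from 30000 nM to 110000 nM.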

Compound 4, half-maximal inhibitory concentration: 53000 nM
Compound 4: the middle estimate sits 1.1-fold (0.04 log units) above what was measured; the range from low to high includes it.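

The new step, a 1.0-fold lower number from compound 3 to compound 4 (0.02 log units; within the scatter), comes from adding one carbon to the sulfur chain, taking but-3-en-1-yl to pent-4-en-1-yl, and in this assay the assay cannot resolve any effect of this change. Set beside the earlier step, the same change gives matching results on the two cores: the same change on two cores in this assay, a 1.1-fold higher number (0.05 log units; within the scatter) from compound 1 to compound 2 and a 1.0-fold lower number (0.02 log units; within the scatter) from compound 3 to compound 4, 1.1-fold (0.06 log units) apart, within the scatter of two such steps This shows that, in these two pairs, the core made no difference that can be resolved, but it does not show that an effect carries from one core to another, since neither step has an effect large enough to follow, and the evidence rests on only two cores with the change at two different places on the chain, on a saturated chain carbon bound to a sulfur and two bonds along the chain from a sulfur.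

The compounds shown leave open whether a longer chain than pent-4-en-1-yl would start to move the number, or whether the same holds once the chain reaches a size where the assay can see a difference. They also leave open what would happen if the end of the chain carried an amine or a carboxylic acid in place of its double bond.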